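Chain extension on the shared core: cytotoxicity working notes

This account rests on a few compounds, and the source may have more. Where it says the series, first, only, none or still open, it means among the compounds named here.

Measured so far:
Compound 1 `CCCCCCCCCCc1cc2cn([C@H]3C[C@H](O)[C@@H](CO)O3)c(=O)nc2o1`: > 50000 nM, a limit of the assay
Compound 2 `CCCCc1cc2cn([C@H]3C[C@H](O)[C@@H](CO)O3)c(=O)nc2s1`: > 200000 nM, a limit of the assay
Compound 3 `CCCCCCCCc1cc2cn([C@H]3C[C@H](O)[C@@H](CO)O3)c(=O)nc2s1`: 53000 nM

Among the compounds with values here, in a functional assay on HEL cells (Homo sapiens) for cytotoxicity (a lower number here means that less compound is tolerated, a higher number that more compound is tolerated), compound 3 gives 53000 nM, the only actual number in the set. Compound 2 sits at the limit of > 200000 nM in this assay, at which 1 of the 3 values shown sits, which is a limit and not a number. Compound 1 sits at the limit of > 50000 nM in this assay, at which 1 of the 3 values shown sits, again a limit rather than a number.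

Within the data shown here, the one measured step that can be read is an at least 3.7-fold lower number from compound 2 to compound 3 (0.57 log units; beyond the scatter); lengthening the chain on the core of compound 3 moved the number down, so less compound was tolerated. Compound 4 `CCCCCCCCCCCCc1cc2cn([C@H]3C[C@H](O)[C@@H](CO)O3)c(=O)nc2s1` differs from compound 3 by butyl in place of hydrogen on a saturated chain carbon, eight bonds along the chain from an aromatic carbon, the same kind of extension carried further out along the chain. Among the measured compounds shown here, with only this single step to lean on, and two of three values being limits, the spread of any expectation is wide; still, the direction from the measured step is the only guide available. For compound 4 a further drop is expected, a 2.1-fold lower number from compound 3 to compound 4 (0.33 log units; beyond the scatter). Compound 4 is therefore estimated at 25000 nM in this assay, with a range from 8000 nM to 80000 nM.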

Compound 4, half-maximal cytotoxic concentration: 49000 nM
Beside the measured number, compound 4's estimate is 2.0-fold (0.29 log units) below it; low and high end bracket the measured number.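

In this assay, a 1.1-fold lower number from compound 3 to compound 4 (0.03 log units; within the scatter) places these two compounds within the scatter of each other, whereas the butyl replacement four bonds along the chain from an aromatic carbon gave an at least 3.7-fold lower number from compound 2 to compound 3 (0.57 log units; beyond the scatter), so the step beyond the scatter does not recur at the position eight bonds along. Over the whole octyl replacement, the reading is an at least 4.0-fold lower number from compound 2 to compound 4 (0.61 log units; beyond the scatter), which lies beyond the scatter and matches the size of the earlier step rather than adding to it. This size is only a lower bound, as compound 2 is a limit and not a number: the limit of > 200000 nM in this assay, at which 1 of the 4 values shown sits.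

Going by these compounds, whether a longer chain, or an amine or a carboxylic acid in place of the butyl, would stay within the scatter of compound 4 remains open. Compound 1 gives no number to set against this series, as its value is also a limit: the limit of > 50000 nM in this assay, at which 1 of the 4 values shown sits.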